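The compounds below may be only part of what the source reports. "The series", "measured", "known", "first", "only" and "open" are said of these compounds alone.

Of the compounds shown here, two that share a core have been measured in an ADME assay on microsomes from liver (Mus musculus) for metabolic stability, read by LC-MS, using NADPH, with a stated time of 45 min, tested at 0.5 uM; on this read-out higher numbers stand for fast clearance and lower numbers for slow clearance. Compound 1, `O=C(CCSc1nc2cc(Cl)ccc2o1)N1CCS(=O)(=O)C1`, gives 8.9 mL/min/g in this assay. Compound 2, `O=C(CCCc1nc2cc(Cl)ccc2o1)N1CCCC1`, gives 115 mL/min/g in this assay. Of these two numbers compound 1 stands lowest, and the gap up to compound 2 lies beyond the scatter. Going by the values given here, no pair among the measured compounds differs in a single place, so no single step has yet been followed.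

Compound 3, `CN1CCN(C(=O)CCSc2nc3cc(Cl)ccc3o2)CC1`, has not been measured. It differs from compound 1 in one place: 4-methylpiperazin-1-yl in place of 1,1-dioxo-1,3-thiazolidin-3-yl on a carbonyl carbon. Among the compounds with values here, nothing among the measured compounds shows how this particular exchange shifts clearance, since compound 2 differs from compound 1 in more than one place. The expected step is a moderate rise in clearance, a 2.8-fold higher number from compound 1 to compound 3 (0.45 log units; beyond the scatter), somewhat beyond the scatter but well short of the gap between the two measured compounds. For compound 3 the estimated value in this assay is 25 mL/min/g, expected to fall between 8 mL/min/g and 80 mL/min/g.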

Compound 3, intrinsic clearance in a liver preparation (reported as CLH), per the amount of preparation that the assay uses: 41.5 mL/min/g
For compound 3 the middle estimate is 1.7-fold (0.22 log units) below the measured one; measured number inside the range.
By their numbers in this assay, from the lowest: compound 1; then compound 3; then compound 2.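

With the rest of compound 1 held fixed, putting 4-methylpiperazin-1-yl in place of 1,1-dioxo-1,3-thiazolidin-3-yl on a carbonyl carbon gives a 4.7-fold higher number from compound 1 to compound 3 (0.67 log units; beyond the scatter) in this assay, so this exchange alone moves clearance beyond the usual scatter. The two groups have the same count of heavy atoms but differ in make-up: a five-membered ring holding sulfur and oxygen leaves, and a six-membered ring holding only carbon and nitrogen enters. No measurement here connects the rise in clearance to any particular feature of either group.

As far as these compounds go, it remains open whether the rise comes from the methyl group or from the ring itself, and comparing an unsubstituted piperazine, a morpholine and a piperidine on the same carbonyl carbon would help separate these possibilities. Also open, from the compounds shown here alone, is what a plain carbon in place of the chain sulfur would do on its own, as compound 2 differs from compound 1 in more than one place and cannot answer that.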